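The source may report more compounds than this note shows. Statements on the series, on what has been measured and on what is new or still open speak of the compounds shown alone.

Measured compounds:
compound 1 `COC(=O)C(c1ccccc1)n1nnnc1[C@@H](COCc1ccccc1)NC(=O)C(C)(C)N`: 20 nM
compound 2 `CC(C)(N)C(=O)N[C@H](COCc1ccccc1)c1nnn(CCCCC#N)n1`: 1860 nM

In a functional assay on H4 cells for agonist activity at growth hormone secretagogue receptor type 1 (Homo sapiens), read by FLIPR (on this read-out lower numbers stand for an effect already at smaller amounts and higher numbers for an effect only at larger amounts of compound), compound 1 gives 20 nM and stands at the lowest of the two measured numbers; compound 2 gives 1860 nM, and the gap between the two lies beyond the scatter. The unmeasured compound 3 `CCCCNC(=O)CCCn1nnnc1[C@@H](COCc1ccccc1)NC(=O)C(C)(C)N` differs from compound 1 in one place: 3-(butylcarbamoyl)propyl in place of methoxycarbonyl)(benzyl on an aromatic nitrogen. Compound 2 is not a single-step neighbour of either compound 1 or compound 3, so its value offers only a hint of direction, nothing more. One would expect compound 3 to move toward higher numbers than compound 1, that is toward an effect only at larger amounts, by an expected step of a 15-fold higher number from compound 1 to compound 3 (1.18 log units; beyond the scatter), a step beyond the scatter. Compound 3 is accordingly estimated at 300 nM, within a range from 60 nM to 1500 nM.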

Compound 3, half-maximal effective concentration: 30 nM
The estimate for compound 3 lay 10-fold (1.00 log units) above the measured number; the measured number lies below the stated range.
By their numbers in this assay, from the lowest: compounds 1 and 3 (each within the scatter of the next); then compound 2.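

In this assay, 3-(butylcarbamoyl)propyl in place of methoxycarbonyl)(benzyl on the aromatic nitrogen gives a 1.5-fold higher number from compound 1 to compound 3 (0.18 log units; within the scatter). This shows that a number at this level does not depend on the six-membered aromatic ring of carbon only or on the methoxycarbonyl group at this position: an open chain with no ring and a different set of hydrogen-bond donors and acceptors serves as well, within the scatter. Nothing in the information available explains why the two groups give such similar numbers.

Which part of the 3-(butylcarbamoyl)propyl chain matters remains open, as the carbamoyl group and the butyl end are exchanged together with the rest. A plain hexyl chain, a carboxylic acid at the chain end or a terminal amine could each separate these parts in this assay.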